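The source may report more compounds than this note shows. Statements on the series, on what has been measured and on what is new or still open speak of the compounds shown alone.

Measured so far in a physicochemical assay for solubility, read by spectrophotometry, measured as kinetic solubility, at pH 8, tested at 500 uM; a lower number here means a less soluble compound, a higher number a more soluble compound:
- compound 1 `Cn1ccc2ccc(-c3cc(Nc4cnccc4C(=O)NCc4cncnc4)cc4nccnc34)cc21`: 233 ug/mL
- compound 2 `CN1CCC(NC(=O)c2ccncc2Nc2cc(-c3ccc4ccn(C)c4c3)c3nccnc3c2)CC1=O`: 48 ug/mL
- compound 3 `Cn1ccc2ccc(-c3cc(Nc4cnccc4C(=O)NCC4COCCN4)cc4nccnc34)cc21`: 239 ug/mL

Not yet measured: compound 4 `CN1CCC(N(C)C(=O)c2ccncc2Nc2cc(-c3ccc4ccn(C)c4c3)c3nccnc3c2)C1`.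

Compound 3 stands level with compound 1: a 1.0-fold higher number from compound 1 to compound 3 (0.01 log units; within the scatter) lies within the scatter, whereas a 5.0-fold higher number from compound 2 to compound 3 (0.70 log units; beyond the scatter) lies beyond it. The next change is methyl(1-methylpyrrolidin-3-yl)amino in place of ((morpholin-3-yl)methyl)amino on a carbonyl carbon. For the measured compounds named here, no measured step makes this exact change, so the three steps on the amide-type nitrogen bear on it only indirectly. Among them, a 4.9-fold lower number from compound 1 to compound 2 (0.69 log units; beyond the scatter) shows that a change there can lower the number in this assay beyond the scatter, while a 1.0-fold higher number from compound 1 to compound 3 (0.01 log units; within the scatter) shows that one can leave it within the scatter. On these data alone, no step beyond the scatter is therefore expected, though the low side stays open. The expected step is a 1.3-fold lower number from compound 3 to compound 4 (0.10 log units; within the scatter). For compound 4 the estimated value is 190 ug/mL, with an expected range of 80 ug/mL to 260 ug/mL.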

Compound 4, solubility: 245 ug/mL
The estimate for compound 4 lay 1.3-fold (0.11 log units) below the measured number; the range from low to high includes it.
By their numbers in this assay, from the lowest: compound 2; then compounds 1, 3 and 4 (each within the scatter of the next).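

On the carbonyl carbon, methyl(1-methylpyrrolidin-3-yl)amino in place of ((morpholin-3-yl)methyl)amino gives (a 1.0-fold higher number from compound 3 to compound 4 (0.01 log units; within the scatter)) in this assay, so the number in this series holds with the amide hydrogen absent and a five-membered ring in place of a six-membered one. Compound 4 also stands level with the (pyrimidin-5-yl)methyl amide (a 1.1-fold higher number from compound 1 to compound 4 (0.02 log units; within the scatter)), leaving the (1-methyl-2-oxopiperidin-4-yl)amino group of compound 2 as the only one apart (a 5.1-fold higher number from compound 2 to compound 4 (0.71 log units; beyond the scatter)). No evidence on hand accounts for these readings.

The compounds shown do not separate the methyl on the amide nitrogen from the pyrrolidine ring, nor show which feature of the 1-methyl-2-oxopiperidin-4-yl group sets compound 2 apart. Also open, on these data alone, is whether an open-chain dimethylaminoethyl group or a carboxylic acid on this amide would keep the number level.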